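Halogen swap on a para-substituted phenyl across two cores

The source may hold more compounds than are shown below. What is called first, only, known or untested is meant among the compounds shown, and "the series" means these compounds.

Compound 1 `CCCCOC1(c2ccc(Cl)cc2)SC=C(C)n2c1noc2=O` and compound 2 `CCCCOC1(c2ccc(Br)cc2)SC=C(C)n2c1noc2=O` share one core and differ only in the halogen: bromo in place of chloro on an aromatic carbon. In a functional assay (Cavia porcellus) with Rattus norvegicus as the target (on this read-out lower numbers stand for an effect already at smaller amounts and higher numbers for an effect only at larger amounts of compound), compound 1 gives 1850 nM, while compound 2 gives 1020 nM. The step of a 1.8-fold lower number from compound 1 to compound 2 (0.26 log units; within the scatter) is therefore small and cannot be read as a real gain.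

Compound 3 `CC1=CS[C@@](OCC2CCCCC2)(c2ccc(Cl)cc2)c2noc(=O)n21` carries a different core; how this core differs from that of compound 1 is not broken down here. In this assay compound 3 gives 240 nM, the lowest of the three numbers, and its distance to both compound 2 and compound 1 lies beyond the scatter.

Compound 4 `CC1=CS[C@@](OCC2CCCCC2)(c2ccc(Br)cc2)c2noc(=O)n21` is not yet measured. It relates to compound 3 exactly as compound 2 relates to compound 1: bromo in place of chloro on an aromatic carbon. The place is the same in both pairs, para to a large group on a six-membered aromatic ring of carbon only, so this is the same change, now made on the core of compound 3.

Among the measured compounds shown here, the only guide for this change is the step of a 1.8-fold lower number from compound 1 to compound 2 (0.26 log units; within the scatter), which stays within the scatter. The step to compound 4 is therefore expected to be of a similar size, a 1.6-fold lower number from compound 3 to compound 4 (0.20 log units; within the scatter), with the same caution that it may be no change at all. Starting from compound 3 at 240 nM, compound 4 is estimated at 150 nM, with a likely range from 60 nM to 400 nM.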

Compound 4, half-maximal effective concentration: 190 nM
The estimate for compound 4 lay 1.3-fold (0.10 log units) below the measured number; low and high end bracket the measured number.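

Bromo in place of chloro on the core of compound 3 gives, in this assay, a 1.3-fold lower number from compound 3 to compound 4 (0.10 log units; within the scatter), so this pair, like compound 1 and compound 2, shows no real gain from the swap. Set beside the earlier step, the change from 4-chlorophenyl to 4-bromophenyl behaves alike on the two cores, with no difference that can be read between them: the same change on two cores in this assay, a 1.8-fold lower number (0.26 log units; within the scatter) from compound 1 to compound 2 and a 1.3-fold lower number (0.10 log units; within the scatter) from compound 3 to compound 4, 1.4-fold (0.16 log units) apart, within the scatter of two such steps

This shows that, on these two cores and in this read-out, the two halogens can stand in for each other without a change beyond the scatter, but it does not show a real effect of the swap that carries from one core to the other, since agreement between two steps this small may be no more than two null results, and it says nothing about any further core.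

Open, going by these compounds, is whether a fluoro, a nitrile or an amine on the same aromatic carbon would move the number beyond the scatter, where the two halogens do not. Among the compounds shown here, also open is which part of the core of compound 3 goes with its lower number relative to compound 1, as these compounds offer no single-place step that links the two cores.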